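The source may hold more compounds than are shown below. What is called first, only, known or untested is meant among the compounds shown, and "the series" means these compounds.

Compound 1 `CC1=CC[C@H](C(C)(C)NC(=S)N/N=C/c2ccccc2)CC1` gives 13000 nM in a functional assay on NCI-H460 cells (Homo sapiens) for inhibition, read by sulforhodamine B assay, with a stated time of 48 h; a lower number here means a stronger inhibitor of growth, a higher number a weaker inhibitor of growth. Compound 2 `CC1=CC[C@H](C(C)(C)NC(=S)N/N=C/c2ccc(O)cc2)CC1` reaches only a limit of this assay, > 100000 nM. Compound 3 `CC1=CC[C@H](C(C)(C)NC(=S)N/N=C/c2cccc([N+](=O)[O-])c2)CC1` likewise stops at a limit, > 100000 nM. The two measured steps, an at least 7.6-fold higher number from compound 1 to compound 2 (0.88 log units; beyond the scatter) and an at least 7.6-fold higher number from compound 1 to compound 3 (0.88 log units; beyond the scatter), run the same way, so compound 2 stands together with compound 3 at the limit of > 100000 nM in this assay, at which 2 of the 3 values shown sit, away from compound 1. Compound 4 `CC1=CC[C@H](C(C)(C)NC(=S)N/N=C/c2cccs2)CC1` carries thiophen-2-yl in place of 4-hydroxyphenyl on a carbon with a double bond to nitrogen. Among the measured compounds shown here, no measured step exchanges the aromatic ring itself; the nearest guide is the reverse of an at least 7.6-fold higher number from compound 1 to compound 2 (0.88 log units; beyond the scatter), which removes the hydroxy along with the ring, so the number for compound 4 is expected to fall back toward that of compound 1. Compound 4 is thus estimated at 20000 nM, within 5000 nM to 100000 nM. The expected step is an at least 5.0-fold lower number from compound 2 to compound 4 (0.69 log units; beyond the scatter).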

Compound 4, concentration for 50% growth inhibition: 10800 nM
Compound 4: middle estimate off by 1.9-fold (0.27 log units), on the high side; low and high end bracket the measured number.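

In this assay, the ring on the carbon with a double bond to nitrogen can be exchanged without a readable change: thiophen-2-yl in place of phenyl gives a 1.2-fold lower number from compound 1 to compound 4 (0.08 log units; within the scatter), so a five-membered aromatic ring serves as well as the unsubstituted phenyl. Thiophen-2-yl in place of 4-hydroxyphenyl gives an at least 9.2-fold lower number from compound 2 to compound 4 (0.96 log units; beyond the scatter). Compound 2 remains a limit, not a number: the limit of > 100000 nM in this assay, at which 2 of the 4 values shown sit.

Still open, going by these compounds, is whether other rings, such as furan-2-yl or pyridin-2-yl, behave like thiophen-2-yl. Also open, on these data alone, is whether a methoxy or an amine on the phenyl ring matches compound 1 or falls to that limit.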